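Branching the Side Chain on a Negative Allosteric Modulator

The source may report more compounds than this note shows. Statements on the series, on what has been measured and on what is new or still open speak of the compounds shown alone.

Measured so far:
compound 1, `CCCN(Cc1cnc(Nc2ccc(C)nc2)c(Cl)c1)C(=O)c1nccs1`, gives 584 nM in a functional assay on HEK293 cells for negative allosteric modulation of metabotropic glutamate receptor 5 (Homo sapiens), read by HTRF and inositol phosphate accumulation; on this read-out lower numbers stand for stronger inhibition and higher numbers for weaker inhibition
compound 2, `CCCC[C@@H](NC(=O)c1nccs1)c1cnc(Nc2ccc(C)nc2)c(Cl)c1`, gives 30.9 nM in this assay

Within the data shown here, of these two numbers, compound 2 has the lower one; the only neighbour, compound 1, sits beyond the usual scatter at the higher end, so compound 2 is the stronger inhibitor of the pair as far as the numbers show. The next compound, compound 3, `Cc1ccc(Nc2ncc([C@H](NC(=O)c3nccs3)C(C)(C)C)cc2Cl)cn1`, keeps every atom of compound 2 and rearranges the side chain: tert-butyl in place of butyl on a saturated chain carbon bound to an amide-type nitrogen and an aromatic carbon. Among the measured compounds shown here, no measured pair shows this kind of rearrangement, so there is no reference step for it. Since nothing is added or removed, the expectation is a step no larger than the scatter, in either direction, from compound 2 to compound 3: a 1.3-fold higher number from compound 2 to compound 3 (0.11 log units; within the scatter). Compound 3 is therefore estimated at 40 nM in this assay, with a range from 10 nM to 160 nM.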

Compound 3, half-maximal inhibitory concentration: 30.9 nM
Compound 3: the middle estimate sits 1.3-fold (0.11 log units) above what was measured; measured number inside the range.
By their numbers in this assay, from the lowest: compounds 2 and 3 (each within the scatter of the next); then compound 1.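

Replacing butyl with tert-butyl on the saturated chain carbon bound to an amide-type nitrogen and an aromatic carbon gives no change at the digits printed from compound 2 to compound 3 (within the scatter) in this assay. Among these compounds, this is the first comparison here that changes one place only, and it shows that at this position, a straight or a branched arrangement of the same four carbons makes no difference that this read-out can separate from the scatter. Nothing available here explains why the two groups read alike.

Two groups with the same carbon count cannot show whether that count itself matters for the numbers in this assay. Going by these compounds, it remains open how this position responds to a shorter chain such as methyl, a longer chain such as hexyl, a phenyl ring, or a chain ending in an amine or a carboxylic acid.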